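Thiazolidine octadecylamides against TSU cells: bromo to cyano

A few compounds are considered here, and "the series" means these few. Any claim that something is new, unique, unknown or untested is made for them only; others in the source may bear on it.

Compound 1, `CCCCCCCCCCCCCCCCCCNC(=O)[C@H]1CSC(C2CCCCC2)N1`. In a functional assay on TSU-Pr1 cells for antiproliferative activity against TSU (Homo sapiens), read by sulforhodamine B assay (on this read-out higher numbers stand for weaker inhibition and lower numbers for stronger inhibition), compound 1 gives > 20000 nM, which is a limit of the assay and not a number.
Compound 2, `CCCCCCCCCCCCCCCCCCNC(=O)[C@H]1CSC(c2ccc(Br)cc2)N1`. In this assay compound 2 gives 18300 nM.

Compound 2 thus holds the only number shown in this assay; the other value is a limit. For the measured compounds named here, the one measured step, an at least 1.0-fold lower number from compound 1 to compound 2 (0.03 log units; that floor lies within the scatter), is read against (the limit of > 20000 nM in this assay, at which 1 of the 2 values shown sits), so its true size is unknown beyond that floor.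

Compound 3, `CCCCCCCCCCCCCCCCCCNC(=O)[C@H]1CSC(c2ccc(C#N)cc2)N1`, is yet to be measured in this assay. It differs from compound 2 by cyano in place of bromo on an aromatic carbon. Going by the values given here, no measured step touches a change on the aromatic ring itself; the only step measured swaps the whole group on the saturated ring carbon and sits at a floor within the scatter. On that basis the step from compound 2 to compound 3 is expected to be small, a 1.0-fold lower number from compound 2 to compound 3 (0.01 log units; within the scatter), with no direction claimed beyond the scatter. Compound 3 is therefore estimated at 18000 nM, between 7000 nM and 45000 nM, with a fair chance that only a limit is returned.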

Compound 3, half-maximal inhibitory concentration: > 20000 nM
Compound 3: a limit, no number (the forecaster's own chance of this, stated with the estimate: 45%); at least 1.1-fold (0.04 log units) between middle value and limit.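

In this assay compound 3 gives > 20000 nM, which is a limit of the assay and not a number. For the compounds shown here, this is the first change read on the aromatic carbon itself: cyano in place of bromo gives an at least 1.0-fold higher number from compound 2 to compound 3 (0.03 log units; that floor lies within the scatter), so the nitrile brings no measurable gain over bromo, while the step between compound 1 and compound 3 cannot be read at all. The true size of the step from bromo to cyano stays unknown, and compound 2 keeps the only number in the set, because the values crowd against the top of the range: the limit of > 20000 nM in this assay, at which 2 of the 3 values shown sit.

Open, on these data alone, is whether any group on this aromatic carbon can bring the number clearly down from the limit, for example an amine, a carboxylic acid or a methoxy group, since two groups there leave no readable trend. Also open, as far as these compounds go, is how much of the weak response belongs to the octadecyl chain on the amide, as all three compounds carry it and a shorter chain or a free carboxylic acid in its place would test the core apart from that chain.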